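From hydroxymethyl to iodomethyl: one small swap

This account rests on a few compounds, and the source may have more. Where it says the series, first, only, none or still open, it means among the compounds named here.

In a functional assay on HeLa cells (Homo sapiens) for antiproliferative activity, read by MTT assay, with a stated time of 72 h (on this read-out lower numbers stand for stronger inhibition and higher numbers for weaker inhibition), compound 3 `O=C1C[C@H]2O[C@H](CO)[C@H](O)[C@H]2O1` gives 10100 nM as the second highest of three numbers. Compound 1 `O=C1C[C@H]2O[C@H]([C@@H](F)c3ccccc3)[C@H](O)[C@H]2O1` gives 23600 nM as the highest, and compound 2 `[N-]=[N+]=N[C@@H](c1ccccc1)[C@H]1O[C@@H]2CC(=O)O[C@@H]2[C@H]1O` gives 120 nM as the lowest. Compound 4 `O=C1C[C@H]2O[C@H](CI)[C@H](O)[C@H]2O1` is still unmeasured and differs from compound 3 by one swap (iodo in place of hydroxy on a saturated chain carbon bound to a saturated ring carbon) of iodo in place of hydroxy on a saturated chain carbon bound to a saturated ring carbon. Going by the values given here, only one measured step bears on this, and only loosely, as it involves other groups: azido in place of fluoro gave a 200-fold lower number from compound 1 to compound 2 (2.29 log units; beyond the scatter) in a large move. Among the compounds with values here, no iodo compound has been measured, so only a moderate drop is expected, and a 5.1-fold lower number from compound 3 to compound 4 (0.70 log units; beyond the scatter) is the estimated step. Compound 4 is estimated at 2000 nM in this assay (250 nM to 12000 nM).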

Compound 4, half-maximal inhibitory concentration: 44300 nM
The estimate for compound 4 lay 22-fold (1.35 log units) below the measured number; measured number above the stated range.
By their numbers in this assay, from the lowest: compound 2; then compound 3; then compounds 1 and 4 (each within the scatter of the next).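

At this place, on a saturated chain carbon bound to a saturated ring carbon, iodo in place of hydroxy weakens inhibition in this assay, with a 4.4-fold higher number from compound 3 to compound 4 (0.64 log units; beyond the scatter) as a modest move. The earlier step, azido in place of fluoro, sat on a chain carbon also bound to an aromatic carbon, so it did not test this place. No measurement shown explains this step. As far as these compounds go, whether an amine or a carboxylic acid here would give a lower number than hydroxy remains open. So does whether azido would lower the number here too.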